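Swapping Back to Thiophene on a Nitro Analog

The source may hold more compounds than are shown below. What is called first, only, known or untested is meant among the compounds shown, and "the series" means these compounds.

Compound 1 `Cc1ccsc1/C=C(/SCc1ccc(Cl)cc1)C(=O)c1ccc(Br)cc1` gives 25000 nM in a functional assay on DU-145 cells (Homo sapiens) for inhibition, read by trypan blue exclusion, with a stated time of 96 h; on this read-out lower numbers stand for stronger inhibition of growth and higher numbers for weaker inhibition of growth. Compound 2 `CN(C)c1ccc(/C=C(/SCc2ccc(Cl)cc2)C(=O)c2ccc(Br)cc2)cc1` gives 10000 nM, with a 2.5-fold lower number from compound 1 to compound 2 (0.40 log units; beyond the scatter). Compound 3 `CN(C)c1ccc(/C=C(/SCc2ccc(Cl)cc2)C(=O)c2ccc([N+](=O)[O-])cc2)cc1` gives > 100000 nM, which is a limit of the assay and not a number. Compound 3 thus sits at the limit of > 100000 nM in this assay, at which 1 of the 3 values shown sits, reached through an at least 10-fold higher number from compound 2 to compound 3 (1.00 log units; beyond the scatter). Compound 4 `Cc1ccsc1/C=C(/SCc1ccc(Cl)cc1)C(=O)c1ccc([N+](=O)[O-])cc1` is not yet measured; it differs from compound 3 by 3-methylthiophen-2-yl in place of 4-(dimethylamino)phenyl on a double-bonded chain carbon bound to a double-bonded chain carbon. Among the compounds with values here, the only measured step bearing on this change runs the opposite way, and gave a 2.5-fold lower number from compound 1 to compound 2 (0.40 log units; beyond the scatter), a modest shift. Reversing it, a modest rise in the number is expected, starting from a value that is already a limit: a step that the limit leaves unreadable from compound 3 to compound 4. Compound 4 is therefore estimated to give 250000 nM, within 100000 nM to 1000000 nM, most likely reported again only as a limit.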

Compound 4, concentration for 50% growth inhibition: > 100000 nM
Compound 4 ended at the assay's limit; the forecaster's own chance of this, stated with the estimate: 85%; the middle value lies beyond the limit too.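

Nitro in place of bromo also weakens growth inhibition on the core carrying 3-methylthiophen-2-yl, with an at least 4.0-fold higher number from compound 1 to compound 4 (0.60 log units; beyond the scatter). The loss is therefore not confined to the core carrying 4-(dimethylamino)phenyl: the same change on two cores in this assay, an at least 10-fold higher number (1.00 log units; beyond the scatter) from compound 2 to compound 3 and an at least 4.0-fold higher number (0.60 log units; beyond the scatter) from compound 1 to compound 4; the limit leaves it open whether they differ The step from compound 3 to compound 4 cannot be read, so the two nitro compounds do not rank these two groups at this place: the limit of > 100000 nM in this assay, at which 2 of the 4 values shown sit.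

On these data alone, how far either nitro compound lies past its limit stays open. So does what methoxy or an amine in place of bromo would give on either core.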